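This account rests on a few compounds, and the source may have more. Where it says the series, first, only, none or still open, it means among the compounds named here.

Measured so far in a functional assay on isolated protein for agonist activity at Glucose-dependent insulinotropic receptor (Rattus norvegicus), read by HTRF and cAMP accumulation; a higher number here means that more compound is needed for the effect, a lower number that less compound is needed:
compound 1 `CS(=O)(=O)c1cnc(O[C@H]2CC[C@H](OC3CCN(C(=O)OC4CCOC4)CC3)CC2)cn1` gives 1500 nM
compound 2 `CS(=O)(=O)c1cnc(O[C@H]2CC[C@H](OC3CCN(C(=O)C4(C(F)(F)F)CC4)CC3)CC2)cn1` gives 1380 nM

Compound 2 stands at the lowest of the two numbers, but the step of a 1.1-fold lower number from compound 1 to compound 2 (0.04 log units; within the scatter) places it within the scatter of compound 1, so the two compounds are not separated.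

Compound 3 `CC(F)Cc1nc(CN2CCC(O[C@H]3CC[C@H](Oc4cnc(S(C)(=O)=O)cn4)CC3)CC2)no1` is not yet measured. It differs from compound 2 by (5-(2-fluoropropyl)-1,2,4-oxadiazol-3-yl)methyl in place of (1-(trifluoromethyl)cyclopropyl)carbonyl on an amine nitrogen in a ring — the group on that amine nitrogen changes from a carbonyl-bearing acyl group to a methylene-linked aromatic ring bearing a 2-fluoropropyl chain.

For the measured compounds named here, the only measured step on this position, a 1.1-fold lower number from compound 1 to compound 2 (0.04 log units; within the scatter), exchanged one carbonyl substituent for another and stayed within the scatter. Going by the values given here, no step among the measured compounds replaces the carbonyl itself, so the change to compound 3 is not covered by the data. With nothing to indicate a direction, the expected step of a 1.1-fold lower number from compound 2 to compound 3 (0.03 log units; within the scatter) is none beyond the scatter, with wide uncertainty.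

Compound 3 is therefore estimated at 1300 nM in this assay, with a range from 300 nM to 5000 nM.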

Compound 3, half-maximal effective concentration: 267 nM
Estimate against measurement, compound 3: 4.9-fold (0.69 log units) above, outside the stated range (below it).
By their numbers in this assay, from the lowest: compound 3; then compounds 2 and 1 (each within the scatter of the next).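

In this assay, the amine nitrogen in a ring proves able to shift the number: (5-(2-fluoropropyl)-1,2,4-oxadiazol-3-yl)methyl on that nitrogen gives a 5.2-fold lower number from compound 2 to compound 3 (0.71 log units; beyond the scatter) and also a 5.6-fold lower number from compound 1 to compound 3 (0.75 log units; beyond the scatter) whereas the exchange of one carbonyl substituent for another left compound 1 and compound 2 unseparated. The change removes the carbonyl on that nitrogen and brings in a five-membered aromatic ring with 3 hetero atoms, so both differences arrive in one step. Nothing measured here accounts for the lower number of compound 3.

Still open, as far as these compounds go, is whether the lower number follows from the loss of the carbonyl, the aromatic ring or the 2-fluoropropyl chain. A plain benzyl group on that nitrogen, or a propyl chain without fluorine on the same aromatic ring, would begin to separate these.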